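Changing the side group of compound 3

The source may hold more compounds than are shown below. What is called first, only, known or untested is meant among the compounds shown, and "the series" means these compounds.

Measured in a physicochemical assay for solubility, read by HPLC, in phosphate buffer, at pH 6.5; on this read-out lower numbers stand for lower solubility and higher numbers for higher solubility:
Compound 1 `COC(=O)C1=C(CN2CCCCC2)NC(c2nccs2)=NC1(C)c1ccc(F)cc1`: 282 ug/mL
Compound 2 `COC(=O)C1=C(CN2CCOCC2=O)NC(c2nccs2)=NC1(C)c1ccc(F)cc1`: 440 ug/mL
Compound 3 `COC(=O)C1=C(CN2CCNC(=O)C2)NC(c2nccs2)=NC1(C)c1ccc(F)cc1`: 34 ug/mL

Among these three, compound 3 has the lowest number, at 34 ug/mL. Compound 4 `COC(=O)C1=C(Cn2ccnc2)NC(c2nccs2)=NC1(C)c1ccc(F)cc1` differs from it in one group, on a saturated chain carbon bound to a double-bonded ring carbon: 1H-imidazol-1-yl in place of 3-oxopiperazin-1-yl on a saturated chain carbon bound to a double-bonded ring carbon. Within the data shown here, no measured compound carries 1H-imidazol-1-yl, so the best guides are the two compounds that lack 3-oxopiperazin-1-yl. The steps are an 8.3-fold lower number from compound 1 to compound 3 (0.92 log units; beyond the scatter) and a 13-fold lower number from compound 2 to compound 3 (1.11 log units; beyond the scatter), whereas a 1.6-fold higher number from compound 1 to compound 2 (0.19 log units; within the scatter). A rise of somewhat smaller size is therefore expected in this assay. The estimated step is a 4.4-fold higher number from compound 3 to compound 4 (0.64 log units; beyond the scatter). For compound 4 the expected value is 150 ug/mL, within an estimated range of 50 ug/mL to 450 ug/mL.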

Compound 4, solubility: 338 ug/mL
Beside the measured number, compound 4's estimate is 2.3-fold (0.35 log units) below it, and the stated range covers the measured number.
By their numbers in this assay, from the lowest: compound 3; then compounds 1, 4 and 2 (each within the scatter of the next).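

Replacing the 3-oxopiperazin-1-yl group with 1H-imidazol-1-yl gives a 9.9-fold higher number from compound 3 to compound 4 (1.00 log units; beyond the scatter) in this assay and shows that a five-membered aromatic ring is tolerated at this position. Against the other two groups, the same ring gives a 1.3-fold lower number from compound 2 to compound 4 (0.11 log units; within the scatter) and a 1.2-fold higher number from compound 1 to compound 4 (0.08 log units; within the scatter), so three different rings sit together and compound 3 alone stands apart. Nothing available explains this.

Going by these compounds, whether a methyl on the amide nitrogen of compound 3 would close that gap remains open. So does where a dimethylamino group or a carboxylic acid would fall.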